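The source may hold more compounds than are shown below. What is called first, only, known or untested is meant among the compounds shown, and "the series" means these compounds.

Measured so far:
compound 1 `Cc1ccc(Nc2cc(NC(=O)Nc3c(Cl)cccc3Cl)ncn2)cc1C` — 84.3%
compound 2 `COc1cc(NC(=O)Nc2cc(Nc3ccc(C)c(F)c3)ncn2)cc(OC)c1` — 72%

In a functional assay on HCC827 cells (Homo sapiens) for inhibition, read by MTT assay, with a stated time of 48 h, tested at 10 uM (on this read-out lower numbers stand for less inhibition and higher numbers for more inhibition at the one concentration tested (going by the name of the read-out)), compound 1 gives 84.3%, the higher of the two numbers shown. Compound 2 gives 72% in this assay, a gap to compound 1 that lies beyond the usual scatter. For the measured compounds named here, compound 2 differs from compound 1 in more than one place, so no single step is read from that pair; the two values stand on their own.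

Compound 3 `COc1ccc(Br)cc1Nc1cc(NC(=O)Nc2c(Cl)cccc2Cl)ncn1` has not yet been measured in this assay. Against compound 1 it differs in one place: 5-bromo-2-methoxyphenyl in place of 3,4-dimethylphenyl on a nitrogen on an aromatic ring

Going by the values given here, no step between measured compounds bears directly on this change, so the expectation rests on compound 1 alone. The step of a number 9.3 percentage points lower from compound 1 to compound 3 (within the scatter) is expected to be small, downward if anything, and possibly not beyond the scatter. Compound 3 is therefore estimated to give about 75% in this assay, with a range from 55% to 90%.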

Compound 3, a percentage reported as inhibition, at one concentration (the size of the read-out at that concentration, not a potency): 53%
Beside the measured number, compound 3's estimate is 22 percentage points above it; measured number below the stated range.
By their numbers in this assay, from the lowest: compound 3; then compound 2; then compound 1.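

The position on a nitrogen on an aromatic ring is not indifferent to the group it carries: in this assay, 5-bromo-2-methoxyphenyl in place of 3,4-dimethylphenyl gives a number 31.3 percentage points lower from compound 1 to compound 3 (beyond the scatter). For the compounds shown here, this is the first single-place step, and it shows that a change confined to this aryl group, with the rest of compound 1 kept, is enough to move the read-out beyond the scatter. Nothing at hand accounts for the size of this step.

The entering group brings bromine and methoxy together, so the compounds shown do not separate the share of each in the step. Also open, as far as these compounds go, is how this position would respond to an aryl group carrying an amine or a carboxylic acid, and whether any such group would hold the level of compound 1.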